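The source may report more compounds than this note shows. Statements on the series, on what has been measured and on what is new or still open speak of the compounds shown alone.

Measured so far in a functional assay on A-431 cells (Homo sapiens) for cytotoxicity, read by MTT assay, with a stated time of 72 h, tested at 1 uM; a higher number here means more inhibition of growth at the concentration tested, a lower number less inhibition of growth: compound 1, `N/C(=N\NC(=S)N1CCCCCC1)c1ccccn1`, gives 18.8%; compound 2, `N/C(=N\NC(=S)N1CCCCC1)c1ccccn1`, gives 24.4%; compound 3, `Cc1ccnc(/C(N)=N/NC(=S)N2CCCCCC2)c1`, gives 36.3%.

Compound 3 differs from compound 1 in one place only: methyl in place of hydrogen on an aromatic carbon. This single change produced a number 17.5 percentage points higher from compound 1 to compound 3 (beyond the scatter). The difference between the cores of compound 1 and compound 2 is not broken down here; their two values lie within the scatter of each other.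

Compound 4, `Cc1ccnc(/C(N)=N/NC(=S)N2CCCCC2)c1`, has not yet been measured in this assay. It differs from compound 2 by the same change, at a place described in the same words: methyl in place of hydrogen on an aromatic carbon. Because the earlier instance gave a number 17.5 percentage points higher from compound 1 to compound 3 (beyond the scatter), a step of similar size is expected here: a number 15.6 percentage points higher from compound 2 to compound 4 (beyond the scatter). This expectation rests on one prior instance of the change, so the range is kept wide. Compound 4 is estimated at about 40%, expected between 27% and 53%.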

Compound 4, percent growth inhibition at one concentration: 31.1%
Compound 4: middle estimate off by 8.9 percentage points, on the high side, and the stated range covers the measured number.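

Methyl in place of hydrogen on an aromatic carbon gives in this assay a number 6.7 percentage points higher from compound 2 to compound 4 (within the scatter) on the core of compound 2, so on this core the change does not stand clear of the scatter. The size of the step on the two cores cannot be told apart: the same change on two cores in this assay, a number 17.5 percentage points higher (beyond the scatter) from compound 1 to compound 3 and a number 6.7 percentage points higher (within the scatter) from compound 2 to compound 4, 10.8 percentage points apart, within the scatter of two such steps. This fits a step that carries over between the two cores, yet two pairs do not show that it does, and they fix no size for it on any further core.

The compounds shown leave open how a longer alkyl chain, a methoxy group or an amine would read in this assay at the place opposite the ring nitrogen. They also leave open whether any such group would give a step that holds on both cores.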